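A few compounds are considered here, and "the series" means these few. Any claim that something is new, unique, unknown or untested is made for them only; others in the source may bear on it.

Measured so far:
Compound 1, `O=c1nc(-c2ccccc2)nc(S)[nH]1`: 4.86% in an assay for inhibition of Pro-cathepsin H (Homo sapiens), read by fluorescence, tested at 50 uM; on this read-out higher numbers stand for more inhibition at the one concentration tested (going by the name of the read-out) and lower numbers for less inhibition
Compound 2, `O=c1nc(SCc2ccccc2)nc(SCc2ccc([N+](=O)[O-])cc2)[nH]1`: "not determined" (no result reported)
Compound 3, `O=c1nc(SCc2ccccc2)nc(SCc2ccc(Cl)cc2)[nH]1`: 6.91%

Compound 3 stands highest of the two numbers available, and its nearest neighbour is compound 1, which lies a little lower, within the usual scatter of this kind of measurement; compound 2 contributes no number. For the measured compounds named here, no pair of measured compounds differs in only one place, so no single step can be read off here.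

Compound 4, `O=C(O)CSc1nc(SCc2ccccc2)nc(=O)[nH]1`, differs from compound 3 as follows: carboxy in place of 4-chlorophenyl on a saturated chain carbon bound to a sulfur. Going by the values given here, with no comparable step to lean on, and with compound 3 at 6.91% close to compound 1, the step of a number 0.9 percentage points lower from compound 3 to compound 4 (within the scatter) is expected to be small, none beyond the scatter, in either direction. Compound 4 is therefore estimated to give 6%, with a range from 0% to 20%.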

Compound 4, a percentage reported as inhibition, at one concentration (the size of the read-out at that concentration, not a potency): 6.89%
Compound 4: the middle estimate sits 0.9 percentage points below what was measured; the range from low to high includes it.
By their numbers in this assay, from the lowest: compounds 1, 4 and 3 (each within the scatter of the next).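

For the compounds shown here, the first single-place comparison in this assay gives a number 0 percentage points lower from compound 3 to compound 4 (within the scatter), so the assay does not separate carboxy from 4-chlorophenyl on a saturated chain carbon bound to a sulfur. At this place, the difference of 4-chlorobenzyl to carboxymethyl, which removes a whole aromatic ring, leaves the two compounds indistinguishable. Nothing available accounts for this result.

Going by these compounds, whether an amine or a longer chain at this place would read differently remains open. So does whether replacing the other benzyl group would matter.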